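Replacing isoquinolin-1-yl with naphthalen-2-yl

This account rests on a few compounds, and the source may have more. Where it says the series, first, only, none or still open, it means among the compounds named here.

Compounds measured so far:
- Compound 1 `O=C(CN1CC=CC[C@H](NC(=O)c2cc(Cl)ccc2Cl)C1=O)N[C@H]1CC(=O)OC1O`: 71 nM
- Compound 2 `O=C(CN1CC=CC[C@H](NC(=O)c2nccc3ccccc23)C1=O)N[C@H]1CC(=O)OC1O`: 586 nM

In a functional assay on THP-1 cells (Homo sapiens) for inhibition (on this read-out lower numbers stand for stronger inhibition and higher numbers for weaker inhibition), compound 2 gives 586 nM, the higher of the two numbers available, and its nearest neighbour is compound 1 at 71 nM. The next compound, compound 3 `O=C(CN1CC=CC[C@H](NC(=O)c2ccc3ccccc3c2)C1=O)N[C@H]1CC(=O)OC1O`, keeps the shared core and changes one group: naphthalen-2-yl in place of isoquinolin-1-yl on a carbonyl carbon. Naphthalen-2-yl takes the place of isoquinolin-1-yl on a carbonyl carbon whose other neighbour is an amide-type nitrogen.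

Within the data shown here, only one measured step bears on this change: an 8.3-fold higher number from compound 1 to compound 2 (0.92 log units; beyond the scatter). In that step, isoquinolin-1-yl replaced 2,5-dichlorophenyl at the same place, and the number rose beyond the scatter. Compound 3 gives up isoquinolin-1-yl, so a move back towards compound 1 at 71 nM seems the likelier direction. Among the measured compounds shown here, no measured compound carries naphthalen-2-yl, however, so only part of that move is expected, and the size remains uncertain. The estimated change is a 2.9-fold lower number from compound 2 to compound 3 (0.47 log units; beyond the scatter). The estimate for compound 3 is 200 nM, with an expected range from 55 nM to 700 nM.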

Compound 3, half-maximal inhibitory concentration: 100 nM
Compound 3: middle estimate off by 2.0-fold (0.30 log units), on the high side; measured number inside the range.
By their numbers in this assay, from the lowest: compounds 1 and 3 (each within the scatter of the next); then compound 2.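

In this assay, naphthalen-2-yl in place of isoquinolin-1-yl on the carbonyl carbon gives a 5.9-fold lower number from compound 2 to compound 3 (0.77 log units; beyond the scatter) and thereby shows that a group with two six-membered aromatic rings can sit at this place without the loss seen in compound 2. Set against 2,5-dichlorophenyl, the same group gives a 1.4-fold higher number from compound 1 to compound 3 (0.15 log units; within the scatter) and so leaves compound 1 and compound 3 indistinguishable on this read-out, while compound 2 remains the weakest of the three and the only one with a ring hetero atom in this group. No measured data are available to explain why the two groups with equal heavy-atom counts behave so differently here.

The step from compound 2 to compound 3 changes both a ring nitrogen to carbon and the attachment named in isoquinolin-1-yl and naphthalen-2-yl, so these two changes cannot be separated with the compounds shown. Naphthalen-1-yl or isoquinolin-3-yl at the same place would pull them apart, and a plain phenyl would show whether the second aromatic ring or the two chlorines matter at all.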